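Replacing Carbamoyl with Methylsulfonyl: A Half-Life Estimate

A few compounds are considered here, and "the series" means these few. Any claim that something is new, unique, unknown or untested is made for them only; others in the source may bear on it.

Measured in an ADME assay on microsomes from liver (Rattus norvegicus) for metabolic stability; a lower number here means that the compound disappears faster, a higher number that the compound lasts longer:
Compound 1 `COc1cc(OCc2csc(-c3ccc(C(F)(F)F)cc3)n2)c2cc(-c3cn4nc(OC)sc4n3)oc2c1`: 1.42 h
Compound 2 `COc1cc(OCc2csc(-c3ccc(C(C)(C)O)cc3)n2)c2cc(-c3cn4nc(OC)sc4n3)oc2c1`: 1.15 h
Compound 3 `COc1cc(OCc2csc(-c3ccc(C(N)=O)cc3)n2)c2cc(-c3cn4nc(OC)sc4n3)oc2c1`: 0.4 h

Compound 3 has the lowest number of the three, at 0.4 h. The next compound, compound 4 `COc1cc(OCc2csc(-c3ccc(S(C)(=O)=O)cc3)n2)c2cc(-c3cn4nc(OC)sc4n3)oc2c1`, keeps the shared core but carries methylsulfonyl in place of carbamoyl on the same aromatic carbon: methylsulfonyl in place of carbamoyl on an aromatic carbon.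

The closest evidence comes from the two measured changes that introduce carbamoyl, which gave a 3.6-fold lower number from compound 1 to compound 3 (0.55 log units; beyond the scatter) and a 2.9-fold lower number from compound 2 to compound 3 (0.46 log units; beyond the scatter). Both are modest but beyond the scatter. Exchanging the two non-carbamoyl groups gave only a 1.2-fold lower number from compound 1 to compound 2 (0.09 log units; within the scatter), which is within the scatter. Removing carbamoyl may therefore recover some of the lost half-life in this assay. However, no measured compound carries methylsulfonyl, so a full return is not assumed, and a modest rise is expected instead. The expected change is a 2.3-fold higher number from compound 3 to compound 4 (0.35 log units; beyond the scatter). The estimated value for compound 4 is 0.9 h, with an expected range from 0.4 h to 1.8 h.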

Compound 4, half-life: 1.12 h
Beside the measured number, compound 4's estimate is 1.2-fold (0.09 log units) below it; the range from low to high includes it.
By their numbers in this assay, from the lowest: compound 3; then compounds 4, 2 and 1 (each within the scatter of the next).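

In this assay, methylsulfonyl in place of carbamoyl gives a 2.8-fold higher number from compound 3 to compound 4 (0.45 log units; beyond the scatter), so a third group on this aromatic carbon now stands clear of carbamoyl. Methylsulfonyl also sits level with the other two groups, with a 1.0-fold lower number from compound 2 to compound 4 (0.01 log units; within the scatter) and a 1.3-fold lower number from compound 1 to compound 4 (0.10 log units; within the scatter), both within the scatter, so among these four compounds carbamoyl alone stands apart, while trifluoromethyl, 1-hydroxy-1-methylethyl and methylsulfonyl cannot be told apart. No measurement at hand bears on why carbamoyl stands apart.

A carboxylic acid, an amine or an amide with a methyl on its nitrogen could land low with compound 3 or level with the other three, and that would show how specific the low number is to carbamoyl. Going by these compounds, whether any group on this carbon can lift the half-life clearly past this level also stays open.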